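The source may hold more compounds than are shown below. What is called first, only, known or untested is meant among the compounds shown, and "the series" means these compounds.

Three ureas on one shared core have been tested in a functional assay on A549 cells (Homo sapiens) for inhibition, read by MTT assay and WST assay, with a stated time of 72 h, tested at 10 uM; a lower number here means less inhibition of growth, a higher number more inhibition of growth at the concentration tested. Compound 1 `O=C(Nc1ccc(Cl)cc1)Nc1ccc(Oc2ccc(-c3ncc[nH]3)cc2)cc1` gives 8.86%. Compound 2 `O=C(Nc1ccc(Oc2ccc(-c3ncc[nH]3)cc2)cc1)Nc1cccc(C(F)(F)F)c1` gives 30%, and compound 3 `O=C(Nc1ccc(Oc2ccc(-c3ncc[nH]3)cc2)cc1)Nc1cc(C(F)(F)F)ccc1Cl` gives 22.3%. Among these three numbers compound 3 stands second highest: its gap to compound 2 is within the scatter, whereas compound 1 lies lower, beyond it. The measured steps are a number 21.1 percentage points higher from compound 1 to compound 2 (beyond the scatter), a number 13.4 percentage points higher from compound 1 to compound 3 (beyond the scatter) and a number 7.7 percentage points lower from compound 2 to compound 3 (within the scatter). Compound 4 `O=C(Nc1ccc(Oc2ccc(-c3ncc[nH]3)cc2)cc1)Nc1cc(Br)cc(C(F)(F)F)c1` has not yet been measured. It differs from compound 3 by 3-bromo-5-(trifluoromethyl)phenyl in place of 2-chloro-5-(trifluoromethyl)phenyl on an amide-type nitrogen, so a halogen again accompanies the trifluoromethyl group and only the halogen is exchanged, as the two group names show. The step that bears most on this change is a number 7.7 percentage points lower from compound 2 to compound 3 (within the scatter), which stayed within the scatter; the larger steps of a number 21.1 percentage points higher from compound 1 to compound 2 (beyond the scatter) and a number 13.4 percentage points higher from compound 1 to compound 3 (beyond the scatter) start from compound 1 and do not concern this exchange. In this assay compound 4 is therefore expected to show a number 2.7 percentage points higher from compound 3 to compound 4 (within the scatter), no step beyond the scatter. The estimate for compound 4 in this assay is 25%, with an expected range from 10% to 42%.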

Compound 4, percent growth inhibition at one concentration: 44.1%
For compound 4 the middle estimate is 19.1 percentage points below the measured one; the measured number lies above the stated range.
By their numbers in this assay, from the lowest: compound 1; then compounds 3 and 2 (each within the scatter of the next); then compound 4.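

In this assay, a halogen added to the 3-(trifluoromethyl)phenyl group now moves the number beyond the scatter, which the earlier chloro step did not do: bromo in place of hydrogen gives a clear gain (a number 14.1 percentage points higher from compound 2 to compound 4 (beyond the scatter)). At an unchanged count of heavy atoms, 3-bromo-5-(trifluoromethyl)phenyl in place of 2-chloro-5-(trifluoromethyl)phenyl on the amide-type nitrogen also raises the number (a number 21.8 percentage points higher from compound 3 to compound 4 (beyond the scatter)), and the largest step comes with its replacement of 4-chlorophenyl (a number 35.2 percentage points higher from compound 1 to compound 4 (beyond the scatter)), leaving compound 4 highest of the four. No evidence is available to explain this gain.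

The compounds shown do not separate the effect of bromine from that of the halogen's place on the ring, as both differ together between compound 3 and compound 4. They also leave open how a nitrile, a methoxy group or an amine would read in place of the bromo.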